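A few compounds are considered here, and "the series" means these few. Any claim that something is new, unique, unknown or untested is made for them only; others in the source may bear on it.

Working notes on the series. Three compounds sharing one core carry a benzyl group on the ring nitrogen: compound 1 `Nc1cc(N)c2nc(-c3ccccc3)c(NCc3ccc(Cl)c(Cl)c3)nc2c1`, compound 2 `COc1ccc(CNc2nc3cc(N)cc(N)c3nc2-c2ccccc2)cc1OC` and compound 3 `Nc1cc(N)c2nc(-c3ccccc3)c(NCc3ccc(F)cc3)nc2c1`. In a functional assay on NCI-H226 cells (Homo sapiens) for inhibition, read by sulforhodamine B assay, with a stated time of 48 h (on this read-out higher numbers stand for weaker inhibition of growth and lower numbers for stronger inhibition of growth), compound 1 gives 22400 nM, compound 2 gives 14500 nM, and compound 3 gives 22400 nM. Compound 3 stands level with compound 1, and compound 2 lies within the scatter of both: a 1.5-fold lower number from compound 1 to compound 2 (0.19 log units; within the scatter), no change at the digits printed from compound 1 to compound 3 (within the scatter), a 1.5-fold higher number from compound 2 to compound 3 (0.19 log units; within the scatter). Across the three benzyl substituents measured so far, no step in this assay leaves the scatter.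

Compound 4 `COc1ccc(CNc2nc3cc(N)cc(N)c3nc2-c2ccccc2)cc1` is not yet measured. It differs from compound 3 by methoxy in place of fluoro on an aromatic carbon. The step that bears most closely on this change is the one from the dimethoxyphenyl to the fluorophenyl compound, a 1.5-fold higher number from compound 2 to compound 3 (0.19 log units; within the scatter), which stayed within the scatter; the two other steps did as well. A number within the scatter of compound 3 is therefore expected for compound 4, and the step of a 1.2-fold lower number from compound 3 to compound 4 (0.09 log units; within the scatter) is estimated as none beyond the scatter, because a 1.5-fold higher number from compound 2 to compound 3 (0.19 log units; within the scatter) showed no more. For compound 4 in this assay the expected value is 18000 nM, with a range from 9000 nM to 36000 nM.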

Compound 4, concentration for 50% growth inhibition: 20400 nM
Compound 4: middle estimate off by 1.1-fold (0.05 log units), on the low side, within the range that was stated.
By their numbers in this assay, from the lowest: compounds 2, 4, 1 and 3 (each within the scatter of the next).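

Among the compounds shown here, the direct exchange of fluoro for methoxy at this place, which the earlier compounds approached only through a step that also altered a second substituent, stays within the scatter in this assay: a 1.1-fold lower number from compound 3 to compound 4 (0.04 log units; within the scatter). Hydrogen in place of one methoxy, a 1.4-fold higher number from compound 2 to compound 4 (0.15 log units; within the scatter), and 4-methoxyphenyl in place of 3,4-dichlorophenyl, a 1.1-fold lower number from compound 1 to compound 4 (0.04 log units; within the scatter), stay within it too, so none of the steps among these four benzyl substituents separates them. No measurement at hand offers an explanation for this flat result.

From the compounds shown here alone, whether an amine or a carboxylic acid on this aromatic carbon, or a longer chain in place of the benzyl group, would give a step beyond the scatter remains open. The compounds shown also leave open whether the same flat result would hold in other cell lines.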